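A few compounds are considered here, and "the series" means these few. Any claim that something is new, unique, unknown or untested is made for them only; others in the source may bear on it.

Measured compounds:
- compound 1, `CNC(=O)c1cc(C(=O)NC2CC2)cc2c1O[C@H](CF)[C@H]2c1ccccc1`: 8 ug/mL
- compound 2, `CNC(=O)c1cc(C(=O)Nc2cnn(C)c2)cc2c1OC[C@H]2c1ccccc1`: >= 189 ug/mL

Compound 1 sits at the low end of the two values in a physicochemical assay for solubility; on this read-out higher numbers stand for higher solubility and lower numbers for lower solubility. The value given for compound 2 in this assay is a limit of the measurement and not a number; compound 2 therefore sits at the limit of >= 189 ug/mL in this assay, at which 1 of the 2 values shown sits, and its actual solubility is not pinned down. Going by the values given here, compound 1 and compound 2 differ in more than one place, so no single step between them is counted.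

Compound 3, `CNC(=O)c1cc(C(=O)NC)c2c(c1)[C@H](c1ccccc1)CO2`, has not yet been measured in this assay. Against compound 2 the change is methyl in place of 1-methyl-1H-pyrazol-4-yl on an amide-type nitrogen. With compound 2 known only as a limit, the expected step is an at least 1.7-fold lower number from compound 2 to compound 3 (0.23 log units; that floor lies within the scatter), a modest downward move, not clearly beyond the scatter. For compound 3 the estimate in this assay is 110 ug/mL, with a range from 35 ug/mL to 250 ug/mL.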

Compound 3, solubility: >= 130 ug/mL
Compound 3: no number, only a limit; the forecaster's own chance of this, stated with the estimate: 35%; middle value at least 1.1-fold (0.07 log units) away from the limit.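

Going by these compounds alone, compound 2 and compound 3 both stand only as limits in this assay, and no step between them can be read. Left open are the actual number for each compound and the size and direction of the change from 1-methyl-1H-pyrazol-4-yl to methyl on an amide-type nitrogen.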